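A few compounds are considered here, and "the series" means these few. Any claim that something is new, unique, unknown or untested is made for them only; others in the source may bear on it.

Measured so far:
compound 1, `COc1cccc(OC)c1OCCNCCOc1ccccc1OCc1ccc(Cl)cc1`, 52500 nM
compound 2, `COc1cccc(OC)c1OCCNCCOc1ccccc1OCc1ccccc1[N+](=O)[O-]`, 95500 nM

Of the compounds shown here, two of the shared core have been tested in a functional assay on PC-3 cells (Homo sapiens) for cytotoxicity, read by sulforhodamine B assay; on this read-out higher numbers stand for lower toxicity in this test and lower numbers for higher toxicity in this test. Compound 1 gives 52500 nM. Within the data shown here, compound 2 gives 95500 nM, the highest of the two numbers; its only neighbour is compound 1, and the step of a 1.8-fold higher number from compound 1 to compound 2 (0.26 log units; within the scatter) is within the scatter, so the two read as equivalent on this assay.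

Compound 3, `COc1cccc(COc2ccccc2OCCNCCOc2c(OC)cccc2OC)c1`, is not yet measured. It differs from compound 2 in one place: 3-methoxyphenyl in place of 2-nitrophenyl on a saturated chain carbon bound to an oxygen on an aromatic ring.

Among the measured compounds shown here, only one measured step bears on this change, namely a 1.8-fold higher number from compound 1 to compound 2 (0.26 log units; within the scatter), which exchanged one substituted phenyl for another at the same place and stayed within the scatter. For the measured compounds named here, no compound with the 3-methoxyphenyl group has been measured, so the direction of the step cannot be read from the data. The expectation for compound 3 in this assay is therefore a step of about a 1.4-fold lower number from compound 2 to compound 3 (0.13 log units; within the scatter), that is, no change beyond the scatter. Compound 3 is expected to give about 70000 nM, with a range from 25000 nM to 200000 nM.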

Compound 3, concentration lethal to 50% of the cells: 61700 nM
For compound 3 the middle estimate is 1.1-fold (0.05 log units) above the measured one, and the stated range covers the measured number.
By their numbers in this assay, from the lowest: compounds 1, 3 and 2 (each within the scatter of the next).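

In this assay, 3-methoxyphenyl in place of 2-nitrophenyl on a saturated chain carbon bound to an oxygen on an aromatic ring stays within the scatter (a 1.5-fold lower number from compound 2 to compound 3 (0.19 log units; within the scatter)), and so does 3-methoxyphenyl in place of 4-chlorophenyl at the same place (a 1.2-fold higher number from compound 1 to compound 3 (0.07 log units; within the scatter)). The earlier pair gave a single exchange at this place, whereas compounds 1, 2 and 3 now give three substituted phenyl groups that all read as equivalent in this assay, with no exception among the compounds shown. Nothing at hand accounts for this flat reading.

Still open, from the compounds shown here alone, is whether the flat reading holds beyond these three groups, for example with an unsubstituted phenyl, a pyridine ring, or a phenyl carrying an amine or a carboxylic acid. Also open, going by these compounds, is whether a longer chain in place of the saturated chain carbon, or a change elsewhere in the shared core, would produce a step beyond the scatter in this assay.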